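Amidine-bearing cyclic ureas as trypsin inhibitors: working notes

A few compounds are considered here, and "the series" means these few. Any claim that something is new, unique, unknown or untested is made for them only; others in the source may bear on it.

Measured so far:
compound 1 `CC1CN(Cc2cccc(C(=N)N)c2)C(=O)N(C2CCN(Cc3ccccc3)CC2)C1` — 4800 nM
compound 2 `CS(=O)(=O)NC1CN(CC2CCN(Cc3ccccc3)CC2)C(=O)N(c2cccc(C(=N)N)c2)C1` — 420 nM

In an assay on isolated protein for inhibition of Trypsin (Homo sapiens), read by fluorescence (on this read-out higher numbers stand for weaker inhibition and lower numbers for stronger inhibition), compound 1 gives 4800 nM, the highest of the two numbers recorded. In this assay compound 2 gives 420 nM, which is a lower number and lies beyond the scatter; the two compounds differ in more than one place, so nothing more is taken from that pair than what the two values show.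

Compound 3 `CC1CN(Cc2ccc(C(=N)N)cc2)C(=O)N(C2CCN(Cc3ccccc3)CC2)C1` is not yet measured. It differs from compound 1 in that the two have the same atoms, joined differently: a group of 9 heavy atoms (7 carbon, 2 nitrogen; one six-membered aromatic ring of carbon only) in place of a group of 9 heavy atoms (7 carbon, 2 nitrogen; one six-membered aromatic ring of carbon only), on a saturated chain carbon bound to an amide-type nitrogen in a ring. Within the data shown here, no pair in the measured set isolates this change, so there is no measured step to lean on. The expectation for this assay is a step from compound 1 to compound 3 of modest size, if any, in the direction of a lower number, but with a range wide enough to include no change beyond the scatter. The estimate for compound 3 in this assay is 2000 nM, between 300 nM and 12000 nM, corresponding to an estimated step of a 2.4-fold lower number from compound 1 to compound 3 (0.38 log units; beyond the scatter).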

Compound 3, inhibition constant: 4800 nM
Beside the measured number, compound 3's estimate is 2.4-fold (0.38 log units) below it, and the stated range covers the measured number.
By their numbers in this assay, from the lowest: compound 2; then compounds 1 and 3 (each within the scatter of the next).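

In this assay, among these compounds, rejoining the atoms of the group on a saturated chain carbon bound to an amide-type nitrogen in a ring gives no change at the digits printed from compound 1 to compound 3 (within the scatter), and this is the first pair that isolates a single change. On the core of compound 1, the two arrangements of this group therefore cannot be told apart in this read-out, although both carry the same atoms and the same counts of donors and acceptors. Nothing available bears on why these two compounds read alike.

As far as these compounds go, what remains open is whether this insensitivity holds with a different group at this place, such as a benzylamine or a benzoic acid in place of the amidine-bearing ring, or with a longer chain joining that ring to the core. From the compounds shown here alone, it is also open whether the same rejoining would matter on the core of compound 2, which differs from compound 1 in more than one place, so that its lower number cannot be assigned to any single feature.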